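The source may hold more compounds than are shown below. What is called first, only, known or untested is meant among the compounds shown, and "the series" means these compounds.

Measured in a functional assay on MCF7 cells (Homo sapiens) for antiproliferative activity, read by sulforhodamine B assay, with a stated time of 72 h; a lower number here means a stronger inhibitor, a higher number a weaker inhibitor:

Compound 1 `O=C(/C=C/c1csc2ccccc12)c1ccccc1O`: 6600 nM
Compound 2 `O=C(/C=C/c1csc2ccccc12)c1cc(F)ccc1O`: > 10000 nM
Compound 3 `O=C(/C=C/c1csc2ccccc12)c1cc(Br)ccc1O`: 1040 nM

The value of compound 2 is a limit of the assay and not a number. Among the measured compounds shown here, compound 3, at 1040 nM, has the lowest value, and compound 1 is the only other compound with a true number.

Compound 4 `O=C(/C=C/c1csc2ccccc12)c1cc(Br)cc(Br)c1O` follows from compound 3 through one change, (bromo in place of hydrogen on an aromatic carbon). A second bromo takes the place of hydrogen on an aromatic carbon, ortho to a hydroxy group and meta to the bromo group already there.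

The closest guide is the earlier exchange of hydrogen for bromo, which gave a 6.3-fold lower number from compound 1 to compound 3 (0.80 log units; beyond the scatter). The exchange of fluoro for bromo gave an at least 9.6-fold lower number from compound 2 to compound 3 (0.98 log units; beyond the scatter), and the exchange of hydrogen for fluoro gave an at least 1.5-fold higher number from compound 1 to compound 2 (0.18 log units; that floor lies within the scatter). None of these steps touched the carbon that changes now, so they offer only a weak guide. For the measured compounds named here, the single bromo precedent points towards a lower number in this assay, but a smaller shift than that earlier one is expected, possibly none beyond the scatter. The expected change is a 1.6-fold lower number from compound 3 to compound 4 (0.20 log units; within the scatter). For compound 4 the estimated value is 650 nM, with an expected range from 200 nM to 2500 nM.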

Compound 4, half-maximal inhibitory concentration: 5800 nM
Compound 4: the middle estimate sits 8.9-fold (0.95 log units) below what was measured, outside the stated range (above it).
By their numbers in this assay, from the lowest: compound 3; then compounds 4 and 1 (each within the scatter of the next). At a limit, above all of these: compound 2.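

In this assay, the same exchange of hydrogen for bromo now runs the other way: on the aromatic carbon ortho to a hydroxy group and meta to a bromo group it gives a 5.6-fold higher number from compound 3 to compound 4 (0.75 log units; beyond the scatter), whereas on the carbon changed earlier it gave a 6.3-fold lower number from compound 1 to compound 3 (0.80 log units; beyond the scatter). The outcome of placing a bromo group in these compounds therefore depends on which carbon carries it and on what the ring already holds, and the lower number seen with the first bromo does not carry over to a second on the same ring. Nothing measured here gives a reason for this reversal.

The compounds shown place only bromo on this carbon, so it remains open whether the higher number belongs to bromo itself or would also appear with a smaller fluoro, a methoxy group or an amine there. Going by these compounds, it is also open how a single bromo on this carbon would read with hydrogen in place of the first bromo, so the contribution of each of the two bromo groups cannot be separated.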